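A few compounds are considered here, and "the series" means these few. Any claim that something is new, unique, unknown or untested is made for them only; others in the source may bear on it.

Compound 1 `O=C(CCCCCCN1C(=O)/C(=N\O)c2ccccc21)NO`, compound 2 `O=C(CCCCCCN1C(=O)/C(=N\O)c2cc(Cl)ccc21)NO` and compound 3 `CO/N=C1/C(=O)N(CCCCCCC(=O)NO)c2ccccc21` all carry a hydroxamic acid; how the core of compound 1 and the core of compound 3 differ is not broken down here. In a functional assay on NCI-H460 cells (Homo sapiens) for antiproliferative activity, read by sulforhodamine B assay, with a stated time of 48 h (a lower number here means a stronger inhibitor, a higher number a weaker inhibitor), compound 1 gives 890 nM. Compound 2 gives 850 nM, the change being (chloro in place of hydrogen on an aromatic carbon), and the step is a 1.0-fold lower number from compound 1 to compound 2 (0.02 log units; within the scatter). Compound 3 gives 750 nM, so the three numbers all lie within the scatter of one another, and none can be called the strongest. Compound 4 `CO/N=C1/C(=O)N(CCCCCCC(=O)NO)c2c(Cl)cccc21` has not yet been measured; it differs from compound 3 by chloro in place of hydrogen on an aromatic carbon. Going by the values given here, this is the same kind of change as the one from compound 1 to compound 2, but not the same: there the chloro sits meta to a fused ring and para to a fused ring, here it sits ortho to a fused ring and meta to a fused ring. The expectation rests on the step of a 1.0-fold lower number from compound 1 to compound 2 (0.02 log units; within the scatter) lying within the scatter. The expected step is therefore a 1.1-fold lower number from compound 3 to compound 4 (0.03 log units; within the scatter). Compound 4 is estimated at 700 nM, with a range from 380 nM to 1300 nM.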

Compound 4, half-maximal inhibitory concentration: 350 nM
Beside the measured number, compound 4's estimate is 2.0-fold (0.30 log units) above it; the measured number lies below the stated range.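

In this assay, chloro in place of hydrogen on an aromatic carbon gives a 2.1-fold lower number from compound 3 to compound 4 (0.33 log units; beyond the scatter), so on the core of compound 3 the change brings a modest gain. Set beside the same change on the core of compound 1, this step cannot be said to differ, and the result neither proves that the change carries over between the two cores nor proves that it depends on the core: the same change on two cores in this assay, a 1.0-fold lower number (0.02 log units; within the scatter) from compound 1 to compound 2 and a 2.1-fold lower number (0.33 log units; beyond the scatter) from compound 3 to compound 4, 2.0-fold (0.31 log units) apart, within the scatter of two such steps. The two pairs also hold the chloro at different places on the aromatic ring, so these compounds cannot separate any effect of the core from an effect of the place, and two pairs establish no rule for the series.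

As far as these compounds go, it remains open whether chloro ortho to a fused ring and meta to a fused ring would give a similar step on the core of compound 1. From the compounds shown here alone, it is also open whether fluoro, bromo or methoxy at that place on the core of compound 3, or a shorter or longer chain leading to the hydroxamic acid, would change the number in this assay.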